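Replacing the Aryl Group on the Cyclopropane in Compound 3

The source may hold more compounds than are shown below. What is called first, only, known or untested is meant among the compounds shown, and "the series" means these compounds.

Compound 1 `CC(C)(C)[C@H](N)CN(C(=O)[C@@H]1C[C@H]1c1ccccc1)c1ccc(-c2ccccc2)cc1` gives 11 nM in a functional assay for agonist activity at G protein-coupled receptor 88 (Homo sapiens), read by HTRF and cAMP accumulation (a lower number here means that less compound is needed, a higher number that more compound is needed for the effect), and compound 2 `CC(C)C[C@H](N)CCN(C(=O)[C@@H]1C[C@H]1c1ccccc1)c1ccc(-c2ccccc2)cc1` gives 3 nM in this assay. Within the data shown here, the one measured step here, a 3.7-fold lower number from compound 1 to compound 2 (0.56 log units; beyond the scatter), concerns the amine-bearing chain, not the aryl group on the cyclopropane, and therefore bears only indirectly on the change considered now.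

Among the measured compounds shown here, compound 3 `CC[C@H](C)[C@H](N)CN(C(=O)[C@@H]1C[C@H]1c1ccccc1Cl)c1ccc(-c2ccccc2)cc1` returns only a limit in this assay, > 25000 nM; it is the one value sitting at the limit of > 25000 nM in this assay, at which 1 of the 3 values shown sits. For the measured compounds named here, compound 3 differs from compounds 1 and 2 both in its amine-bearing chain and in the chlorine on the phenyl ring, so no single step links it to either of them.

Compound 4 `CC[C@H](C)[C@H](N)CN(C(=O)[C@@H]1C[C@H]1c1ccc(F)c(F)c1)c1ccc(-c2ccccc2)cc1` differs from compound 3 in one place: 3,4-difluorophenyl in place of 2-chlorophenyl on a saturated ring carbon. Going by the values given here, no measured step covers a change of the aryl group on the cyclopropane, so the direction of the step cannot be read from the data. Since compound 3 stands at a limit, any recovered activity would register as a large step, while the same outcome as compound 3 remains possible. Compound 4 is therefore expected to lie around 6000 nM, within 300 nM to 25000 nM, which corresponds to the expected step of an at least 4.1-fold lower number from compound 3 to compound 4 (0.61 log units; beyond the scatter).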

Compound 4, half-maximal effective concentration: 720 nM
Compound 4: middle estimate off by 8.3-fold (0.92 log units), on the high side; measured number inside the range.
By their numbers in this assay, from the lowest: compound 2; then compound 1; then compound 4. At a limit, above all of these: compound 3.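

In this assay, the aryl group on the cyclopropane proves to be a place where one change separates a limit from a measured value: 3,4-difluorophenyl in place of 2-chlorophenyl gives an at least 34-fold lower number from compound 3 to compound 4 (1.54 log units; beyond the scatter). On these data alone, compound 3 gives > 25000 nM, which is a limit and not a number, so the true size of this step stays unknown and the printed size is only its smallest possible value: the limit of > 25000 nM in this assay, at which 1 of the 4 values shown sits. With the amine-bearing chain of compound 3 kept, compound 4 gives 720 nM, so that chain does not by itself rule out a measured value in this assay.

The step swaps the whole aryl group, so the compounds shown cannot say how much of it comes from losing the chlorine on the 2-position group and how much from gaining the two fluorines. Also open, as far as these compounds go, is how an unsubstituted phenyl, a 4-fluorophenyl or a 3,4-dichlorophenyl would stand on this same chain, and each of these would help to separate the effect of the chain from that of the aryl group.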